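Swapping the acyl group on a chemokine receptor ligand

The compounds below may be only part of what the source reports. "The series", "measured", "known", "first", "only" and "open" are said of these compounds alone.

The measured compounds are:
compound 1, `CC(C)C(NC(=O)c1ccccc1)C(=O)N1CCC(c2ccc(F)cc2)CC1`, 423 nM
compound 2, `Cc1ccccc1CCC(=O)N[C@@H](C(=O)N1CCC(c2ccc(Cl)cc2)CC1)C(C)C`, 19 nM
compound 3, `CC[C@@H](C)[C@@H](NC(=O)CC(C)C)C(=O)N1CCC(c2ccc(Cl)cc2)CC1`, 34 nM

In an assay on THP-1 cells for displacement of a labelled ligand from C-C chemokine receptor type 1 (Homo sapiens) (on this read-out lower numbers stand for stronger inhibition and higher numbers for weaker inhibition), compound 2 gives the lowest of the three numbers. Compound 3 stands nearest to it, and the gap between the two lies within the scatter, so they cannot be told apart on these numbers. Compound 1 stands furthest away, with a number far beyond the scatter.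

The unmeasured compound 4, `CC(C)[C@@H](NC(=O)c1ccc(F)cc1)C(=O)N1CCC(c2ccc(Cl)cc2)CC1`, is derived from compound 2 by a single change: 4-fluorophenyl in place of 2-(2-methylphenyl)ethyl on a carbonyl carbon. Going by the values given here, no direct step between measured compounds matches this change. Compound 1 also carries an aromatic ring directly on the carbonyl carbon, and in this assay compound 1 gives 423 nM, but compound 1 differs from compound 4 in more than one place, so its value serves only as a rough pointer.

On that basis, a step toward weaker binding is expected, and the expected step of a 7.9-fold higher number from compound 2 to compound 4 (0.90 log units; beyond the scatter) is beyond the scatter. Compound 4 is estimated to give 150 nM in this assay, with a range from 50 nM to 450 nM.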

Compound 4, half-maximal inhibitory concentration: 118 nM
Compound 4: middle estimate off by 1.3-fold (0.10 log units), on the high side, and the stated range covers the measured number.
By their numbers in this assay, from the lowest: compounds 2 and 3 (each within the scatter of the next); then compound 4; then compound 1.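

In this assay, going by these compounds alone, the step from the 2-(2-methylphenyl)ethyl group to 4-fluorophenyl on the carbonyl carbon gives a 6.2-fold higher number from compound 2 to compound 4 (0.79 log units; beyond the scatter), the first single-place step in this set and the first direct sign that the number responds to the group at this position. The step is beyond the scatter even though both groups hold one six-membered aromatic ring of carbon only, with no hydrogen-bond donors or acceptors and no net charge, so these shared counts alone do not keep the number in place; the groups differ in size by only 9 against 7 heavy atoms. No measurement here bears on why the number moves.

The change removes the ethyl link and exchanges the methyl for a fluorine in one step, so the compounds shown leave open which part goes with the higher number, a question that a 2-(4-fluorophenyl)ethyl group on the same carbonyl carbon would help to settle. Also open, on these data alone, is how this position would respond to a group of another kind, such as a chain ending in an amine or a carboxylic acid.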